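A few compounds are considered here, and "the series" means these few. Any claim that something is new, unique, unknown or untested is made for them only; others in the source may bear on it.

In an ADME assay on HEK293 cells (Homo sapiens) for cytotoxicity, with a stated time of 72 h (a higher number here means that more compound is needed for the effect, a lower number that less compound is needed), compound 2 `Cc1ccc(-c2nc3ccccc3s2)cc1NC(=O)c1cc([N+](=O)[O-])c(N2CCC(C(=O)O)CC2)cc1Cl` gives > 25000 nM, which is a limit and not a number. Compound 1 `O=C(O)COc1cc(Cl)c(C(=O)Nc2cccc(-c3nc4ccccc4s3)c2)cc1[N+](=O)[O-]` gives > 25000 nM, also a limit. Compound 3 `O=C(Nc1nc2ccc(Cl)cc2s1)c1cc([N+](=O)[O-])ccc1Cl`, which carries no 4-carboxypiperidin-1-yl, gives > 27000 nM, again a limit. Among the measured compounds shown here, compound 2 therefore cannot be ranked against the other two, and no measured step is available as a guide. Compound 4 `Cc1ccc(-c2nc3ccccc3s2)cc1NC(=O)c1cc([N+](=O)[O-])c(N(C)C)cc1Cl` has dimethylamino in place of 4-carboxypiperidin-1-yl on an aromatic carbon of compound 2: dimethylamino in place of 4-carboxypiperidin-1-yl on an aromatic carbon. The limit of compound 3 is the nearest hint that losing this group need not matter much. The expected step of an at least 1.1-fold lower number from compound 2 to compound 4 (0.05 log units; that floor lies within the scatter) is small, towards less compound needed, and may stay within the usual scatter. For compound 4 the estimated value is 22000 nM, with an expected range from 7000 nM to 40000 nM.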

Compound 4, half-maximal effective concentration: > 25000 nM
Compound 4: only a limit was reported; the forecaster's own chance of this, stated with the estimate: 60%; at least 1.1-fold (0.05 log units) between middle value and limit.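

Compound 2 and compound 4 both give only a limit in this assay, and the step between them cannot be read. From the compounds shown here alone, whether dimethylamino in place of 4-carboxypiperidin-1-yl changes the concentration needed for the effect stays open.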